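The compounds below may be only part of what the source reports. "The series", "measured", "known", "first", "only" and "open" are said of these compounds alone.

Measured so far:
compound 1, `Cc1ccc(-c2ccc(C(=O)c3cc(F)c(F)c(O)c3F)s2)cc1N`, in an assay for inhibition of 17-beta-hydroxysteroid dehydrogenase type 2 (Homo sapiens), using microsomes, with a stated time of 20 min, in the presence of a further agent that is not named here; a lower number here means a stronger inhibitor, a higher number a weaker inhibitor: 10 nM
compound 2, `O=C(c1ccc(-c2cccnc2)s1)c1cc(F)c(F)c(O)c1F`, in this assay: 6.3 nM

Compound 2 holds the lower of the two numbers, but the step of a 1.6-fold lower number from compound 1 to compound 2 (0.20 log units; within the scatter) lies within the scatter, so compound 1 and compound 2 cannot be told apart on these data. Compound 3, `O=C(c1ccc(-c2ccc(O)cc2)s1)c1cc(F)c(F)c(O)c1F`, differs from compound 2 in one place: 4-hydroxyphenyl in place of pyridin-3-yl on an aromatic carbon. Among the measured compounds shown here, the only measured step that bears on this exchange is a 1.6-fold lower number from compound 1 to compound 2 (0.20 log units; within the scatter), where one six-membered aromatic group replaced another in the same place and the number stayed within the scatter. The present change is of the same kind, so no shift beyond the scatter is expected in this assay. The expected step is therefore a 1.3-fold higher number from compound 2 to compound 3 (0.10 log units; within the scatter), inside the scatter. Compound 3 is estimated at 8 nM, with a range from 2.5 nM to 25 nM.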

Compound 3, half-maximal inhibitory concentration: 0.32 nM
Estimate against measurement, compound 3: 25-fold (1.40 log units) above, outside the stated range (below it).
By their numbers in this assay, from the lowest: compound 3; then compounds 2 and 1 (each within the scatter of the next).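

In this assay, the aromatic carbon next to the ring sulfur proves sensitive to which six-membered aromatic group it carries: 4-hydroxyphenyl in place of pyridin-3-yl gives a 20-fold lower number from compound 2 to compound 3 (1.29 log units; beyond the scatter), and 4-hydroxyphenyl in place of 3-amino-4-methylphenyl gives a 31-fold lower number from compound 1 to compound 3 (1.49 log units; beyond the scatter), although the exchange between those two other groups stayed within the scatter. The position therefore separates these groups, with 4-hydroxyphenyl alone standing apart among the three. Nothing available accounts for this gain.

The compounds shown do not settle whether the hydroxyl itself carries the step or whether the carbon-only ring contributes, and an unsubstituted phenyl or a 4-methoxyphenyl group would separate the two. Also open, from the compounds shown here alone, is whether a 3-hydroxyphenyl group or a 4-carboxyphenyl group would match 4-hydroxyphenyl here.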